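From an aromatic to a non-aromatic ring: compound 4

The source may hold more compounds than are shown below. What is called first, only, known or untested is meant among the compounds shown, and "the series" means these compounds.

In a functional assay on T47D cells (Homo sapiens) for cytotoxicity, read by MTT assay, with a stated time of 48 h (a lower number here means a stronger inhibitor, a higher number a weaker inhibitor), compound 1 (`C[n+]1cccc(OP(=O)([O-])OC[C@H]2O[C@@H](n3cc(F)c(=O)[nH]c3=O)C[C@@H]2OC(=O)c2ccccc2)c1`) gives 3910 nM, compound 2 (`CCCCCCCCCC[n+]1cccc(OP(=O)([O-])OC[C@H]2O[C@@H](n3cc(F)c(=O)[nH]c3=O)C[C@@H]2OC(=O)c2ccccc2)c1`) gives 8730 nM and compound 3 (`CCOC(=O)C[n+]1cccc(OP(=O)([O-])OC[C@H]2O[C@@H](n3cc(F)c(=O)[nH]c3=O)C[C@@H]2OC(=O)c2ccccc2)c1`) gives 12700 nM. Compound 3 therefore sits level with compound 2, with a 1.5-fold higher number from compound 2 to compound 3 (0.16 log units; within the scatter), and both are weaker than compound 1.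

Compound 4 (`C[N+]1(C)CCC(OP(=O)([O-])OC[C@H]2O[C@@H](n3cc(F)c(=O)[nH]c3=O)C[C@@H]2OC(=O)c2ccccc2)CC1`) departs further from this set: a group of 8 heavy atoms (7 carbon, 1 nitrogen; one six-membered non-aromatic ring with 1 hetero atom) in place of a group of 12 heavy atoms (9 carbon, 1 nitrogen, 2 oxygen; one six-membered aromatic ring with 1 hetero atom), on an oxygen. One six-membered non-aromatic ring with 1 hetero atom now stands where one six-membered aromatic ring with 1 hetero atom stood.

The measured steps bear on this only indirectly. They alter a saturated chain carbon bound to an aromatic nitrogen, and they are modest: a 2.2-fold higher number from compound 1 to compound 2 (0.35 log units; beyond the scatter) and a 3.2-fold higher number from compound 1 to compound 3 (0.51 log units; beyond the scatter). None of them replaces the ring itself, so the data offer no direct guide to this swap. With all three values lying close together, no large move is expected. In this assay the estimated change is a 1.6-fold lower number from compound 3 to compound 4 (0.20 log units; within the scatter), which is not expected to go beyond the scatter. Compound 4 is expected at 8000 nM, with an estimated range from 2500 nM to 30000 nM.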

Compound 4, half-maximal inhibitory concentration: 11900 nM
For compound 4 the middle estimate is 1.5-fold (0.17 log units) below the measured one; low and high end bracket the measured number.
By their numbers in this assay, from the lowest: compound 1; then compounds 2, 4 and 3 (each within the scatter of the next).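

Replacing the six-membered aromatic ring on the oxygen bound to phosphorus with a six-membered non-aromatic ring changes little in this assay: the step is a 1.1-fold lower number from compound 3 to compound 4 (0.03 log units; within the scatter) and so the aromatic ring is not needed to keep this level of cytotoxicity. Compared with the methyl-bearing ring of compound 1, however, the non-aromatic ring gives a 3.0-fold higher number from compound 1 to compound 4 (0.48 log units; beyond the scatter) and thus joins the nonyl and ethoxycarbonyl changes, each of which also gave a modest rise from compound 1. No supporting measurement accounts for these numbers.

As far as these compounds go, it remains open how a phenyl ring with no ring nitrogen, or a five-membered ring, would behave on this oxygen. Whether any replacement for the ring of compound 1 can give a lower number also remains unanswered.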